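This account rests on a few compounds, and the source may have more. Where it says the series, first, only, none or still open, it means among the compounds named here.

Measured in an in vivo ADME assay on the whole organism (Cavia porcellus); a higher number here means that the compound lasts longer, a lower number that the compound disappears faster:
compound 1 `CC(NC(=O)c1ccc(C(=N)N)cc1)C(C)(C)C(=O)N1CCC(CC(=O)O)CC1` — 0.883 h
compound 2 `CCCC(NC(=O)c1ccc(C(=N)N)cc1)C(C)(C)C(=O)N1CCC(CC(=O)O)CC1` — 0.9 h
compound 3 `CC(C)(C(=O)N1CCC(CC(=O)O)CC1)C(NC(=O)c1ccc(C(=N)N)cc1)c1ccc(Cl)cc1` — 1.2 h

Compound 2 holds the second highest of the three numbers; both neighbours lie within the scatter of it, a 1.0-fold higher number from compound 1 to compound 2 (0.01 log units; within the scatter) and a 1.3-fold higher number from compound 2 to compound 3 (0.12 log units; within the scatter). Compound 4 `CC(C)(C(=O)N1CCC(CC(=O)O)CC1)C(NC(=O)c1ccc(C(=N)N)cc1)c1ccc(O)cc1` differs from compound 2 by one change: 4-hydroxyphenyl in place of propyl on a saturated chain carbon bound to an amide-type nitrogen and a saturated chain carbon. Going by the values given here, the steps that bear on it are those placing 4-chlorophenyl on the same carbon, a 1.3-fold higher number from compound 2 to compound 3 (0.12 log units; within the scatter) and a 1.4-fold higher number from compound 1 to compound 3 (0.13 log units; within the scatter), both within the scatter. Among the compounds with values here, no measured compound carries 4-hydroxyphenyl, so that part of the change rests on nothing. The expected step is therefore none beyond the scatter, a 1.1-fold higher number from compound 2 to compound 4 (0.05 log units; within the scatter). For compound 4 the estimate is 1 h, ranging from 0.5 h to 2 h.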

Compound 4, half-life: 1.05 h
Estimate against measurement, compound 4: 1.1-fold (0.02 log units) below; the range from low to high includes it.
By their numbers in this assay, from the lowest: compounds 1, 2, 4 and 3 (each within the scatter of the next).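

In this assay, 4-hydroxyphenyl on the saturated chain carbon bound to an amide-type nitrogen and a saturated chain carbon stays level with the open-chain groups it replaces, a 1.2-fold higher number from compound 2 to compound 4 (0.07 log units; within the scatter) and a 1.2-fold higher number from compound 1 to compound 4 (0.08 log units; within the scatter). Hydroxy in place of chloro on an aromatic carbon, the first change made on that ring itself, also stays within the scatter, a 1.1-fold lower number from compound 3 to compound 4 (0.06 log units; within the scatter). Nothing on hand explains this flat picture.

Still open, going by these compounds, is whether an amine or a carboxylic acid in place of hydroxy on that aromatic carbon, or a longer chain in place of propyl, would move the half-life beyond the scatter.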